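Ester-to-acid step in a trifluorobenzyl indole series

The source may hold more compounds than are shown below. What is called first, only, known or untested is meant among the compounds shown, and "the series" means these compounds.

Measured so far:
compound 1 `COc1cccc2c1c(C(=O)/C=C(\O)C(=O)O)cn2Cc1ccc(F)c(F)c1F`, an ADME assay on MT4 cells (Homo sapiens) for cytotoxicity, read by MTT assay; a higher number here means that more compound is tolerated, a lower number that less compound is tolerated: 22800 nM
compound 2 `CCOC(=O)/C(O)=C/C(=O)c1cn(Cc2c(F)ccc(F)c2F)c2cccc(OC)c12`, this assay: 40500 nM

Compound 2 gives the number at the upper end of the two, yet its gap to compound 1 lies within the usual scatter, so the two values give no order. Compound 3 `COc1cccc2c1c(C(=O)/C=C(\O)C(=O)O)cn2Cc1c(F)ccc(F)c1F` is compound 2 with hydrogen in place of ethyl on an oxygen next to a carbonyl group. For the measured compounds named here, no step of this kind has been measured here; the expectation is a step of roughly the size seen between compound 1 and compound 2, downward or none beyond the scatter. Compound 3 is estimated at 25000 nM, range 10000 nM to 60000 nM, which means an expected step of a 1.6-fold lower number from compound 2 to compound 3 (0.21 log units; within the scatter).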

Compound 3, half-maximal cytotoxic concentration: 49400 nM
Estimate against measurement, compound 3: 2.0-fold (0.30 log units) below; the measured number falls inside the stated range.
By their numbers in this assay, from the lowest: compounds 1, 2 and 3 (each within the scatter of the next, the first and the last beyond it).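

In this assay, hydrogen in place of ethyl on an oxygen next to a carbonyl group gives a 1.2-fold higher number from compound 2 to compound 3 (0.09 log units; within the scatter) and so sets no order between the ethoxycarbonyl and carboxy forms. For the compounds shown here, with the carboxy group kept, 2,3,6-trifluorophenyl in place of 2,3,4-trifluorophenyl gives a 2.2-fold higher number from compound 1 to compound 3 (0.34 log units; beyond the scatter) as the only step here beyond the scatter, and a modest one. Nothing available bears on the cause of either step.

Open, on these data alone, is whether ethoxycarbonyl and carboxy also read alike with 2,3,4-trifluorophenyl. Also open, as far as these compounds go, is how a primary amide or a longer ester chain reads at this position.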